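The source may report more compounds than this note shows. Statements on the series, on what has been measured and on what is new or still open speak of the compounds shown alone.

Measured so far:
- compound 1 `CCCn1c(=O)[nH]c2nc(-c3ccc(S(=O)(=O)N4CCN(c5cccc(Br)c5)CC4)cc3)[nH]c2c1=O`: in an assay on CHO cells for displacement of a labelled ligand from adenosine receptor A3 (Homo sapiens), read by scintillation counting, with a stated time of 45 min, in the presence of a further agent that is not named here (on this read-out higher numbers stand for weaker inhibition and lower numbers for stronger inhibition), compound 1 gives > 1000 nM, a limit of the assay.
- compound 2 `CCCn1c(=O)[nH]c2nc(-c3ccc(S(=O)(=O)N4CCN(Cc5cccc(Br)c5)CC4)cc3)[nH]c2c1=O`: compound 2 gives > 1000 nM, again a limit.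
- compound 3 `CCCn1c(=O)[nH]c2nc(-c3ccc(S(=O)(=O)N4CCN(C(C)c5ccccc5)CC4)cc3)[nH]c2c1=O`: compound 3 gives > 1000 nM, also a limit.

Compound 3 thus stands only at a limit, as do the other two values, all at the limit of > 1000 nM in this assay, at which 3 of the 3 values shown sit. Compound 4 `CCCn1c(=O)[nH]c2nc(-c3ccc(S(=O)(=O)N4CCN(c5ccc(C)cc5)CC4)cc3)[nH]c2c1=O` differs from compound 3 by 4-methylphenyl in place of 1-phenylethyl on an amine nitrogen in a ring. The measured steps a step that the two limits leave unreadable from compound 1 to compound 3, a step that the two limits leave unreadable from compound 2 to compound 3 and a step that the two limits leave unreadable from compound 1 to compound 2 are all unreadable in size, so no direction can be drawn from them. Compound 4 is expected near 3000 nM, within 1000 nM to 10000 nM. The expected step is a step that the limit leaves unreadable from compound 3 to compound 4, with a further limit the most likely outcome.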

Compound 4, inhibition constant: > 1000 nM
Compound 4: a limit, no number; the forecaster's own chance of this, stated with the estimate: 85%; the middle value is on the limit's open side.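

In this assay, going by these compounds alone, the result for compound 4 is a limit, not a number, so no step among compound 1, compound 2, compound 3 and compound 4 can be read: the limit of > 1000 nM in this assay, at which 4 of the 4 values shown sit. As far as these compounds go, whether these four compounds differ from one another in this assay stays open.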